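A Saturated Ring in Place of Phenyl on a Urea

A few compounds are considered here, and "the series" means these few. Any claim that something is new, unique, unknown or untested is made for them only; others in the source may bear on it.

Of the compounds shown here, three sharing one core have been tested in a functional assay on MCF7 cells (Homo sapiens) for cytotoxicity, read by MTT assay, with a stated time of 48 h; on this read-out lower numbers stand for stronger inhibition and higher numbers for weaker inhibition. Compound 1 `COc1cc(CN(C(=O)Nc2ccc(C)cc2)n2cnnc2)cc(OC)c1OC` gives > 50000 nM in this assay, a limit of the assay rather than a number. Compound 2 `O=C(Nc1ccccc1)N(Cc1ccccn1)n1cnnc1` gives > 50000 nM in this assay, again a limit and not a number. Compound 3 `Cc1ccsc1CN(C(=O)Nc1cccc(C#N)c1)n1cnnc1` gives > 50000 nM in this assay, also a limit. Within the data shown here, compound 2 thus stands at the limit of > 50000 nM in this assay, at which 3 of the 3 values shown sit; since no compound has a measured number, no step between measured compounds can be sized.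

Compound 4 `CC1CCC(NC(=O)N(Cc2ccccn2)n2cnnc2)CC1` has not yet been measured. It differs from compound 2 in one place: 4-methylcyclohexyl in place of phenyl on an amide-type nitrogen. Among the measured compounds shown here, with every value resting at the limit, there is no measured step to lean on, and the expectation is that potency stays where it is, with any step in this assay no larger than the usual scatter. Compound 4 is therefore expected to give about 60000 nM in this assay, within a range from 25000 nM to 150000 nM. The expected step in this assay is a step that the limit leaves unreadable from compound 2 to compound 4, nothing beyond the scatter.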

Compound 4, half-maximal inhibitory concentration: 34000 nM
The estimate for compound 4 lay 1.8-fold (0.25 log units) above the measured number; measured number inside the range.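

Putting 4-methylcyclohexyl in place of phenyl on the amide-type nitrogen gives an at least 1.4-fold lower number from compound 2 to compound 4 (0.16 log units; that floor lies within the scatter) in this assay. This shows that an aromatic ring at this place is not needed for a compound of this set to give a real number, and compound 4 gives 34000 nM. Still, the step is only a floor and its true size cannot be read, and compound 4 is the one compound here that escapes the limit: the limit of > 50000 nM in this assay, at which 3 of the 4 values shown sit.

Whether the saturated ring or its methyl group accounts for the change stays open, and a plain cyclohexyl at the same place would separate the two. Going by these compounds, how a longer chain in place of the ring, or an amine or a carboxylic acid on it, would read in this assay is also open.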